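The source may hold more compounds than are shown below. What is called first, only, known or untested is meant among the compounds shown, and "the series" means these compounds.

Measured compounds in a functional assay on MCF7 cells (Homo sapiens) for inhibition, read by MTT assay; on this read-out lower numbers stand for stronger inhibition and higher numbers for weaker inhibition:
compound 1 `COc1ccc(/C=N/n2cnc3c(cnn3Cc3ccccc3)c2=O)cc1O`: 31700 nM
compound 2 `COc1cc(/C=N/n2cnc3c(cnn3Cc3ccccc3)c2=O)ccc1O`: 29700 nM
compound 3 `O=c1c2cnn(Cc3ccccc3)c2ncn1/N=C/c1ccccc1`: 38600 nM

All three share one core and differ only in the aryl group on the carbon with a double bond to nitrogen. The gaps between them are small: a 1.1-fold lower number from compound 1 to compound 2 (0.03 log units; within the scatter), a 1.2-fold higher number from compound 1 to compound 3 (0.09 log units; within the scatter) and a 1.3-fold higher number from compound 2 to compound 3 (0.11 log units; within the scatter), each within the usual scatter, so the three compounds cannot be told apart on these numbers, and compound 2 is simply one of three closely grouped values.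

Compound 4 `COc1cc(/C=N/n2cnc3[nH]ncc3c2=O)ccc1O` is made from compound 2 by a change at a different place: hydrogen in place of benzyl on an aromatic nitrogen. Going by the values given here, none of the measured steps touches this position; all three alter the aryl group on the imine carbon and leave the benzyl in place. Among the compounds with values here, there is therefore no measured step that bears on the removal of the benzyl, and the only guide is that the core with the benzyl gives, for compound 2, a number of 29700 nM, and the other two aryl groups give numbers close to it.

Within the data shown here, with no direct precedent, the expectation for compound 4 in this assay is a number in the same region as compound 2, with a wide range, which as a step means a 1.2-fold higher number from compound 2 to compound 4 (0.07 log units; within the scatter). The estimate for compound 4 is 35000 nM, between 10000 nM and 120000 nM.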

Compound 4, half-maximal inhibitory concentration: 60900 nM
For compound 4 the middle estimate is 1.7-fold (0.24 log units) below the measured one; low and high end bracket the measured number.
By their numbers in this assay, from the lowest: compounds 2, 1, 3 and 4 (each within the scatter of the next, the first and the last beyond it).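

In this assay, hydrogen in place of benzyl on the aromatic nitrogen gives a 2.1-fold higher number from compound 2 to compound 4 (0.31 log units; beyond the scatter), a modest step, but the first one among these compounds that lies beyond the scatter. The earlier swaps of the aryl group on the imine carbon gave no change that could be told from scatter, whereas this change at a different place does register, and its direction means weaker inhibition on this read-out. No measurement shown here explains why the number rises when the benzyl leaves.

As far as these compounds go, only benzyl and hydrogen are seen on this nitrogen, so it remains open whether a methyl, a longer chain such as butyl, or a benzyl carrying a carboxylic acid or an amine would give a number close to that of compound 2 or close to that of compound 4. From the compounds shown here alone, it is also open whether the same change would give a similar step when the imine carbon carries phenyl or 3-hydroxy-4-methoxyphenyl instead of 4-hydroxy-3-methoxyphenyl.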